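A few compounds are considered here, and "the series" means these few. Any claim that something is new, unique, unknown or untested is made for them only; others in the source may bear on it.

Compound 2, `COc1ccc2nccc(C3CN(C4CCN(Cc5cc6ccccc6s5)CC4)C(=O)O3)c2c1`, was tested in an in vitro functional assay on RBL cells for antagonist activity at C-C chemokine receptor type 8 (Homo sapiens), read by FLIPR and calcium flux (on this read-out higher numbers stand for weaker inhibition and lower numbers for stronger inhibition), where compound 2 gives 794 nM. Of the two numbers at hand this is the higher one; the other comes from compound 1, `COc1ccc2nccc(C3CN(C4CCN(Cc5cc6ccccc6[nH]5)CC4)C(=O)O3)c2n1`, which in this assay gives 31.6 nM, a gap that lies beyond the usual scatter. The two structures differ in more than one place, so their values are simply set side by side here.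

Compound 3, `COc1ccc2nccc(C3CN(C4CCN(Cc5cccc(Cl)c5)CC4)C(=O)O3)c2c1`, carries the change (3-chlorophenyl in place of 1-benzothiophen-2-yl on a saturated chain carbon bound to an amine nitrogen in a ring). Going by the values given here, no pair of measured compounds shows this particular exchange, so there is no measured step to lean on. With compound 2 already at the weak end, the expected step from compound 2 to compound 3 is a 1.4-fold higher number from compound 2 to compound 3 (0.14 log units; within the scatter), that is, little movement beyond the scatter, with a slight lean toward a higher number. For compound 3 in this assay the estimate is 1100 nM, within a range from 300 nM to 4000 nM.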

Compound 3, half-maximal inhibitory concentration: 6310 nM
Estimate against measurement, compound 3: 5.7-fold (0.76 log units) below, outside the stated range (above it).
By their numbers in this assay, from the lowest: compound 1; then compound 2; then compound 3.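

At the saturated chain carbon bound to an amine nitrogen in a ring, 3-chlorophenyl in place of 1-benzothiophen-2-yl gives clearly weaker inhibition in this assay (a 7.9-fold higher number from compound 2 to compound 3 (0.90 log units; beyond the scatter)). This is the first exchange in one place among the compounds shown, and it shows that the read-out responds to this group while the rest of compound 2 stays unchanged. Nothing measured here bears on the reason for this step.

A single step cannot separate the loss of the five-membered aromatic ring from the arrival of the chlorine. From the compounds shown here alone, how a plain phenyl or a naphthalen-2-yl group would compare on the core of compound 2 remains open, as does whether the same exchange would give a step of similar size on the core of compound 1.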